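A few compounds are considered here, and "the series" means these few. Any claim that something is new, unique, unknown or untested is made for them only; others in the source may bear on it.

Measured so far:
compound 1 `CN(C)CCNc1nc(-c2ccc(NC(=O)Nc3ccccc3Cl)cc2)nc2ccsc12` — 850 nM
compound 2 `CCN(CC)CCNc1nc(-c2ccc(NC(=O)Nc3ccccc3F)cc2)nc2ccsc12` — 1040 nM

In a functional assay on MKN-45 cells (Homo sapiens) for cytotoxicity, read by MTT assay, with a stated time of 72 h (a lower number here means a stronger inhibitor, a higher number a weaker inhibitor), compound 1 gives 850 nM and compound 2 gives 1040 nM. Among the measured compounds shown here, compound 2 holds the highest of the two numbers, yet its gap to compound 1 lies within the scatter, so the two read as equal; they also differ in two places, so no single step connects them.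

Compound 3 `CCN(CC)CCNc1nc(-c2ccc(NC(=O)Nc3ccccc3Cl)cc2)nc2ccsc12` is not yet measured. It differs from compound 2 by chloro in place of fluoro on an aromatic carbon, placed on an aromatic carbon of a six-membered aromatic ring of carbon only, ortho to a large group. For the measured compounds named here, no measured pair shows this exchange alone, so no size of step is known. Compound 1, which carries the chloro group on a different amine chain, gives 850 nM, close to compound 2. The expectation is therefore no change beyond the scatter in this assay, with the step of a 1.2-fold lower number from compound 2 to compound 3 (0.06 log units; within the scatter) estimated as small. Compound 3 is expected to give about 900 nM, within 400 nM to 2000 nM.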

Compound 3, half-maximal inhibitory concentration: 750 nM
Compound 3: the middle estimate sits 1.2-fold (0.08 log units) above what was measured; the measured number falls inside the stated range.
By their numbers in this assay, from the lowest: compounds 3, 1 and 2 (each within the scatter of the next).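

In this assay chloro in place of fluoro on an aromatic carbon, ortho to a large group, now has a size of its own: a 1.4-fold lower number from compound 2 to compound 3 (0.14 log units; within the scatter) shows that the two groups cannot be told apart at this position. The amine chain also gets its first single-place reading, as diethylamino in place of dimethylamino with the chloro group held fixed gives a 1.1-fold lower number from compound 1 to compound 3 (0.05 log units; within the scatter) and so leaves the two chains equal here too. No measurement is available that could explain either step.

From the compounds shown here alone, only fluoro and chloro have been seen at this position, so it remains open whether a methoxy group, a nitrile or plain hydrogen would give a step beyond the scatter. Going by these compounds, on the chain, a morpholine, a piperidine or a longer chain carrying the amine remains equally open.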